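A few compounds are considered here, and "the series" means these few. Any claim that something is new, unique, unknown or untested is made for them only; others in the source may bear on it.

Measured so far:
compound 1 `Cc1nn(-c2ncnc3nc[nH]c23)c2c1C(OCC(=O)c1ccc(F)cc1)CC(=O)N2` — 3 nM
compound 2 `Cc1nn(-c2ncnc3nc[nH]c23)c2c1C(C(=O)Nc1ccccc1)CC(=O)N2` — 10 nM
compound 3 `Cc1nn(-c2ncnc3nc[nH]c23)c2c1C(OCc1ccccc1C#N)CC(=O)N2` — 8 nM

All three share one core and differ only in the group on the saturated ring carbon. In a functional assay on HEK293 cells for agonist activity at G-protein coupled receptor 39 (Homo sapiens), read by scintillation proximity assay and inositol phosphate accumulation, with a stated time of 75 min, in the presence of a further agent that is not named here (a lower number here means that less compound is needed, a higher number that more compound is needed for the effect), compound 2 gives the highest of the three numbers. Its nearest neighbour is compound 3, a step of a 1.3-fold lower number from compound 2 to compound 3 (0.10 log units; within the scatter), which is within the scatter; its furthest is compound 1, whose value of 3 nM lies beyond the scatter from compound 2.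

Compound 4 `Cc1nn(-c2ncnc3nc[nH]c23)c2c1C(C(=O)NCc1ccccc1)CC(=O)N2` is not yet measured. It differs from compound 2 by benzyl in place of phenyl on an amide-type nitrogen. Among the compounds with values here, no measured step touches this nitrogen: a 2.7-fold higher number from compound 1 to compound 3 (0.43 log units; beyond the scatter) swaps groups on the ether chain of compound 1, and a 1.3-fold lower number from compound 2 to compound 3 (0.10 log units; within the scatter) exchanges the whole phenylcarbamoyl group for (2-cyanobenzyl)oxy. Both steps show that the side group on this ring carbon can be varied with only small to modest movement, so for compound 4 a step of about a 1.5-fold higher number from compound 2 to compound 4 (0.18 log units; within the scatter) is expected, with no clear direction beyond the scatter. The estimate for compound 4 in this assay is 15 nM, in a range from 4 nM to 50 nM.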

Compound 4, half-maximal effective concentration: 5 nM
For compound 4 the middle estimate is 3.0-fold (0.48 log units) above the measured one, within the range that was stated.
By their numbers in this assay, from the lowest: compounds 1, 4, 3 and 2 (each within the scatter of the next, the first and the last beyond it).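

In this assay, the first change shown on the amide-type nitrogen, benzyl in place of phenyl, gives a 2.0-fold lower number from compound 2 to compound 4 (0.30 log units; within the scatter), so the two groups cannot be told apart at this nitrogen. The carbamoyl and ether side groups also stay within the scatter of each other here: benzylcarbamoyl in place of (2-cyanobenzyl)oxy on the saturated ring carbon gives a 1.6-fold lower number from compound 3 to compound 4 (0.20 log units; within the scatter). Nothing available explains these small steps.

Still open, going by these compounds, is how this nitrogen responds to a group without an aromatic ring, such as a methyl group or a longer alkyl chain. Also open, on these data alone, is what a nitrile or a fluorine on the benzyl ring would do, or an amine or a carboxylic acid at the end of this side group.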